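Two measured chalcone analogues and a combined third

The source may report more compounds than this note shows. Statements on the series, on what has been measured and on what is new or still open speak of the compounds shown alone.

Measured compounds:
compound 1, `COc1cc(/C=C/C(=O)c2cccc(-n3cc(-c4ccccc4)[nH]c3=O)c2)cc(OC)c1OC`, 4030 nM
compound 2, `COc1ccc(-c2cn(-c3cccc(C(=O)/C=C/c4ccc(O)c(OC)c4)c3)c(=O)[nH]2)cc1`, 4140 nM

In a functional assay on A549 cells (Homo sapiens) for inhibition (on this read-out lower numbers stand for stronger inhibition of growth and higher numbers for weaker inhibition of growth), compound 2 gives 4140 nM, and compound 1 gives 4030 nM in this assay, a gap within the scatter. Compound 3, `COc1ccc(-c2cn(-c3cccc(C(=O)/C=C/c4cc(OC)c(OC)c(OC)c4)c3)c(=O)[nH]2)cc1`, carries 3,4,5-trimethoxyphenyl in place of 4-hydroxy-3-methoxyphenyl on a double-bonded chain carbon bound to a double-bonded chain carbon. Compound 1 already shows this same trimethoxyphenyl group with a value in this assay that stands level with compound 2, so no step beyond the scatter is expected here. Compound 3 is therefore estimated at 4000 nM, between 1800 nM and 9000 nM, which would mean an expected step of a 1.0-fold lower number from compound 2 to compound 3 (0.01 log units; within the scatter).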

Compound 3, concentration for 50% growth inhibition: 11800 nM
The estimate for compound 3 lay 3.0-fold (0.47 log units) below the measured number, outside the stated range (above it).
By their numbers in this assay, from the lowest: compounds 1 and 2 (each within the scatter of the next); then compound 3.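

In this assay, putting 3,4,5-trimethoxyphenyl in place of 4-hydroxy-3-methoxyphenyl on this chain carbon is not neutral: it gives a 2.9-fold higher number from compound 2 to compound 3 (0.45 log units; beyond the scatter), towards weaker inhibition of growth. Methoxy in place of hydrogen on an aromatic carbon, with the trimethoxyphenyl group kept, gives a 2.9-fold higher number from compound 1 to compound 3 (0.47 log units; beyond the scatter), so the level values of the two earlier compounds had hidden that each single change weakens inhibition. No evidence at hand explains either step. On these data alone, it remains open how an amine or a carboxylic acid in place of that methoxy would read in this assay.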